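A pyridone in place of a methylpyridine

The source may hold more compounds than are shown below. What is called first, only, known or untested is meant among the compounds shown, and "the series" means these compounds.

Two compounds share one core and differ in a single group. Compound 1 `C[C@@H](O[C@H]1CN2C(=O)C=C(c3ccncc3)CC2[C@@H]1c1ccc(F)cc1)c1cc(C(F)(F)F)cc(C(F)(F)F)c1` gives 0.14 nM in an assay on CHO cells for displacement of a labelled ligand from Substance-P receptor (Homo sapiens); a lower number here means a stronger inhibitor, a higher number a weaker inhibitor. Compound 2 `Cc1cc(C2=CC(=O)N3C[C@H](O[C@H](C)c4cc(C(F)(F)F)cc(C(F)(F)F)c4)[C@@H](c4ccc(F)cc4)C3C2)ccn1` gives 0.51 nM in this assay; of the two numbers it is the higher one, and the step of a 3.6-fold higher number from compound 1 to compound 2 (0.56 log units; beyond the scatter) shows that a methyl added on an aromatic carbon weakened binding beyond the scatter. Compound 3 `C[C@@H](O[C@H]1CN2C(=O)C=C(c3cc[nH]c(=O)c3)CC2[C@@H]1c1ccc(F)cc1)c1cc(C(F)(F)F)cc(C(F)(F)F)c1` has not yet been measured; it differs from compound 2 by a group of 7 heavy atoms (5 carbon, 1 nitrogen, 1 oxygen; one six-membered aromatic ring with 1 hetero atom) in place of a group of 7 heavy atoms (6 carbon, 1 nitrogen; one six-membered aromatic ring with 1 hetero atom), on a double-bonded ring carbon. For the measured compounds named here, no measured step matches this change directly: the only measured step, a 3.6-fold higher number from compound 1 to compound 2 (0.56 log units; beyond the scatter), concerns a methyl and gives just a hint that changes on this ring can move the number. For compound 3 a step of a 2.0-fold higher number from compound 2 to compound 3 (0.29 log units; within the scatter) is therefore expected, a modest rise that may still fall within the scatter. The estimate for compound 3 is 1 nM, within a range from 0.2 nM to 5 nM.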

Compound 3, half-maximal inhibitory concentration: 0.27 nM
Compound 3: the middle estimate sits 3.7-fold (0.57 log units) above what was measured; the measured number falls inside the stated range.
By their numbers in this assay, from the lowest: compounds 1, 3 and 2 (each within the scatter of the next, the first and the last beyond it).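

In this assay the double-bonded ring carbon accepts a pyridone in place of 2-methylpyridin-4-yl, with a 1.9-fold lower number from compound 2 to compound 3 (0.28 log units; within the scatter) as the result. Set against the unsubstituted pyridine ring of compound 1, the same pyridone gives a 1.9-fold higher number from compound 1 to compound 3 (0.29 log units; within the scatter), so a ring with a hydrogen-bond donor stays within the scatter of both earlier compounds, even though those two lie beyond the scatter of each other. No supporting measurement is available to explain this result.

The compounds shown leave open how an amine, a carboxylic acid or a longer chain on this ring would register in this assay. They also leave open whether the amide hydrogen of the pyridone matters for the number at all, which a methyl in its place could test.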